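Notes on methyl removal at a ring nitrogen

The compounds below may be only part of what the source reports. "The series", "measured", "known", "first", "only" and "open" are said of these compounds alone.

Measured so far:
compound 1, `CC(C)(C)c1nc(N)ncc1-c1ccccc1`: in a functional assay on the whole organism for inhibition, with Rattus norvegicus as the target, with stated times of 1 h and 3.5 h, at a dose of 100 mg/kg by the oral route (on this read-out lower numbers stand for less inhibition and higher numbers for more inhibition at the one dose given (going by the name of the read-out)), compound 1 gives 46%
compound 2, `CNc1ncc(-c2ccccc2)c(C(C)(C)C)n1`: in this assay compound 2 gives 37%
compound 3, `CN(C)c1nccc(C(C)(C)C)n1`: in this assay compound 3 gives 18%

Compound 1 differs from compound 2 by hydrogen in place of methyl on a nitrogen on an aromatic ring; that change gave a number 9 percentage points higher from compound 2 to compound 1 (within the scatter). Compound 3 stands lowest of the three, with both gaps to the others beyond the scatter. How the core of compound 3 differs from that of compound 2 is not broken down here.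

Compound 4, `CNc1nccc(C(C)(C)C)n1`, is still unmeasured; from compound 3 it differs by hydrogen in place of methyl on a nitrogen on an aromatic ring. This is the same kind of change as from compound 2 to compound 1, though the nitrogen in compound 3 has as other neighbours an aromatic carbon and a saturated chain carbon, where in compound 2 it has an aromatic carbon only.

Because a number 9 percentage points higher from compound 2 to compound 1 (within the scatter) stayed within the scatter, compound 4 is expected to give a number 7 percentage points higher from compound 3 to compound 4 (within the scatter) in this assay. Compound 4 is thus estimated at 25%, between 10% and 42%.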

Compound 4, a percentage reported as inhibition, in the whole organism at one dose (the size of the read-out at that dose, not a potency): 34%
Compound 4: the middle estimate sits 9 percentage points below what was measured; measured number inside the range.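

Hydrogen in place of methyl on a nitrogen on an aromatic ring gives, in this assay, a number 16 percentage points higher from compound 3 to compound 4 (beyond the scatter). Set beside the earlier step, the change carries from one core to the other with no difference in size that can be read: the same change on two cores in this assay, a number 9 percentage points higher (within the scatter) from compound 2 to compound 1 and a number 16 percentage points higher (beyond the scatter) from compound 3 to compound 4, 7 percentage points apart, within the scatter of two such steps. This rests on two pairs only; it does not show that the step would hold on a further core, nor why one step falls within the scatter and the other beyond it.

Hydrogen in place of phenyl on an aromatic carbon gives a number 3 percentage points lower from compound 2 to compound 4 (within the scatter), and that single pair is all there is for this place. Still open, going by these compounds, are a longer chain on that nitrogen and a carboxylic acid or an amine in place of the phenyl.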